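This account rests on a few compounds, and the source may have more. Where it says the series, first, only, none or still open, it means among the compounds named here.

Measured compounds in a functional assay on SN12C cells (Homo sapiens) for cytotoxicity, read by sulforhodamine B assay, with a stated time of 48 h; a higher number here means a weaker inhibitor of growth, a lower number a stronger inhibitor of growth:
- compound 1 `ClCc1ccccc1Cn1cnc2c(Cl)nc(Cl)nc21` gives 2040 nM
- compound 2 `ClCc1cccc(Cn2cnc3c(Cl)nc(Cl)nc32)c1` gives 4670 nM
- compound 3 `Nc1nc(Cl)c2ncn(Cc3ccccc3CCl)c2n1` gives 5620 nM

Compound 1 and compound 2 contain the same atoms joined differently; the difference between the two cores is not broken down here. Their values lie beyond the scatter of each other, whereas compound 2 and compound 3 lie within it, so no order between those two is claimed.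

Compound 3 differs from compound 1 by amino in place of chloro on an aromatic carbon. Measured, this gave a 2.8-fold higher number from compound 1 to compound 3 (0.44 log units; beyond the scatter), a modest weakening. Compound 4 `Nc1nc(Cl)c2ncn(Cc3cccc(CCl)c3)c2n1`, not yet measured, differs from compound 2 by amino in place of chloro on an aromatic carbon; the place is described in the same words, so this is the same change on the other core.

Within the data shown here, compound 4 is expected to show a step of a 2.8-fold higher number from compound 2 to compound 4 (0.44 log units; beyond the scatter) because the single measured instance of this change gave a 2.8-fold higher number from compound 1 to compound 3 (0.44 log units; beyond the scatter). Among the measured compounds shown here, with only one precedent and a different core, the range is kept wide. Compound 4 is therefore estimated at 13000 nM, expected to fall between 6000 nM and 30000 nM.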

Compound 4, concentration for total growth inhibition: 15500 nM
Compound 4: the middle estimate sits 1.2-fold (0.08 log units) below what was measured, within the range that was stated.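

Replacing chloro with amino on the aromatic carbon between two ring nitrogen atoms gave, in this assay, a 3.3-fold higher number from compound 2 to compound 4 (0.52 log units; beyond the scatter), and this step agrees with the one measured on the other core: the same change on two cores in this assay, a 2.8-fold higher number (0.44 log units; beyond the scatter) from compound 1 to compound 3 and a 3.3-fold higher number (0.52 log units; beyond the scatter) from compound 2 to compound 4, 1.2-fold (0.08 log units) apart, within the scatter of two such steps

The change therefore carried over from the core of compound 1 to the core of compound 2 with a similar size and the same direction, and no difference between the two cores can be claimed for this step. This rests on one pair per core and on one cell line, so it does not show that the step would hold on other cores or in other cells, nor does it explain why the number rises.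

The compounds shown leave open whether other groups on that carbon, such as methylamino or methoxy, would give a step like that of amino. Also open, on these data alone, is what happens when the chloro group kept in compound 3 and compound 4 gives way to an amine or a longer chain.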